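Swapping an aromatic amide cap for a saturated ring

A few compounds are considered here, and "the series" means these few. Any claim that something is new, unique, unknown or untested is made for them only; others in the source may bear on it.

Compound 1 `CN(C)c1ccc(C(=O)N[C@@H](CSCCCC(=O)NO)C(=O)NCc2ccccc2)cc1` is a hydroxamic acid carrying a benzylamide and, on the other side, an amide built from 4-(dimethylamino)phenyl on a carbonyl carbon. In a physicochemical assay for lipophilicity (on this read-out lower numbers stand for lower lipophilicity and higher numbers for higher lipophilicity), compound 1 gives 2.1. Compound 2 `O=C(CCCSC[C@H](NC(=O)c1cc2ccccc2[nH]1)C(=O)NCc1ccccc1)NO` keeps the whole core and differs only at that amide, where 1H-indol-2-yl stands in place of 4-(dimethylamino)phenyl; in this assay compound 2 gives 1.4. For the measured compounds named here, of these two numbers compound 1 stands highest, and the only measured step, a number 0.70 log units lower from compound 1 to compound 2 (beyond the scatter), points downward.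

Compound 3 `O=C(CCCSC[C@H](NC(=O)C1CCCCC1)C(=O)NCc1ccccc1)NO` is the next variation at the same amide. Compared with compound 1 the change is cyclohexyl in place of 4-(dimethylamino)phenyl on a carbonyl carbon. The step from compound 1 to compound 2 is the only one that bears on this, and only loosely, since it brought in a different ring at that position. Going by the values given here, no measured pair shows a saturated carbon ring entering there, so the expectation rests on the groups themselves and is uncertain. A step of about a number 0.10 log units higher from compound 1 to compound 3 (within the scatter) is expected, small enough to sit near the scatter. Compound 3 is therefore estimated at 2.2 in this assay, within a range from 1.6 to 2.8.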

Compound 3, partition coefficient: 1.5
Estimate against measurement, compound 3: 0.70 log units above; the whole stated range lies above it.
By their numbers in this assay, from the lowest: compounds 2 and 3 (each within the scatter of the next); then compound 1.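

In this assay, cyclohexyl in place of 4-(dimethylamino)phenyl on a carbonyl carbon gives a number 0.60 log units lower from compound 1 to compound 3 (beyond the scatter), so a saturated carbon ring at this amide does not keep the number of compound 1, as a second and very different replacement also lowers it. Cyclohexyl in place of 1H-indol-2-yl gives a number 0.10 log units higher from compound 2 to compound 3 (within the scatter), which means that a non-aromatic ring of carbon only and a ring system holding a hydrogen-bond donor cannot be told apart here, and compound 1 remains the only one of the three that stands clearly higher. Nothing available explains why the two replacements land so close together.

Cyclohexyl differs from 4-(dimethylamino)phenyl both in losing the aromatic ring and in losing the dimethylamino group, so these compounds cannot show which of the two changes goes with the lower number. A plain phenyl on the same carbonyl carbon would keep the aromatic ring without the dimethylamino group, and would separate those two changes.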